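Removing a Ring Methyl from a Deubiquitinase Inhibitor

The source may report more compounds than this note shows. Statements on the series, on what has been measured and on what is new or still open speak of the compounds shown alone.

Compound 1 `Cc1cc(Cl)cc(-c2ccnc3cc(CN4C(=O)C5C(C4=O)C5(C)C)sc23)c1C[C@@H]1CNCCO1` gives 0.44 nM in an assay on isolated protein for inhibition of ubiquitin carboxyl-terminal hydrolase 7 (Homo sapiens), read by fluorescence, with stated times of 30 min and 1 h; a higher number here means a weaker inhibitor, a lower number a stronger inhibitor.
Compound 2 `Cc1cc(Cl)cc(-c2ccnc3cc(CN4C(=O)C5CC5C4=O)sc23)c1C[C@@H]1CNC[C@@H](C)O1` gives 0.39 nM in this assay.
Compound 3 `Cc1cc(Cl)cc(-c2ccnc3cc(CN4C(=O)C5CC5C4=O)sc23)c1C[C@H]1OCCN[C@@H]1C` gives 1.5 nM in this assay.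

Compound 3 stands highest of the three numbers in this assay. Compound 1 is nearest to it and compound 2 furthest, the two sitting close to one another. Going by the values given here, the one measured step that reaches compound 3 is a 3.8-fold higher number from compound 2 to compound 3 (0.59 log units; beyond the scatter), a modest rise that came from moving the ring methyl from the 6-methylmorpholin-2-yl arrangement to the 3-methylmorpholin-2-yl one.

Compound 4 `Cc1cc(Cl)cc(-c2ccnc3cc(CN4C(=O)C5CC5C4=O)sc23)c1C[C@@H]1CNCCO1` differs from compound 3 in a single place: hydrogen in place of methyl on a saturated ring carbon. Among the compounds with values here, no measured step removes this methyl outright, so the expectation rests on comparison. Compound 1 carries the same morpholin-2-yl that compound 4 will have, and compound 2 differs from compound 4 only by a methyl in the 6-position, and both gave low numbers. Compound 4 is therefore expected to move back down by a modest step, a 3.0-fold lower number from compound 3 to compound 4 (0.48 log units; beyond the scatter), toward those two. The estimated value for compound 4 in this assay is 0.5 nM, within a range of 0.2 nM to 1.2 nM.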

Compound 4, half-maximal inhibitory concentration: 0.16 nM
Compound 4: middle estimate off by 3.1-fold (0.49 log units), on the high side; the whole stated range lies above it.
By their numbers in this assay, from the lowest: compound 4; then compounds 2 and 1 (each within the scatter of the next); then compound 3.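

In this assay, the unsubstituted morpholin-2-yl proves better than either methylated ring shown: taking the methyl off the saturated ring carbon next to the ring nitrogen gives the largest change in the series (a 9.4-fold lower number from compound 3 to compound 4 (0.97 log units; beyond the scatter)), and removing the methyl of the 6-methylmorpholin-2-yl also counts beyond the scatter (a 2.4-fold lower number from compound 2 to compound 4 (0.39 log units; beyond the scatter)), so compound 2 had not marked the floor for this series. The other end of the molecule matters as well, since with the morpholin-2-yl held constant, the group of compound 4, which is smaller than the one it replaces, also gives a lower number (a 2.8-fold lower number from compound 1 to compound 4 (0.44 log units; beyond the scatter)), a difference that compound 1 alone could not reveal. Nothing measured here accounts for any of these steps.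

The compounds shown leave open whether an ethyl, a hydroxymethyl or a fluorine on that saturated ring carbon would raise the number as methyl does. They also leave open how a second methyl on the morpholine, or an N-methyl on its ring nitrogen, would behave alongside the smaller group of compound 4.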